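This account rests on a few compounds, and the source may have more. Where it says the series, first, only, none or still open, it means among the compounds named here.

In an ADME assay for permeability, using PAMPA, at pH 7.4 (a higher number here means that the compound crosses the layer faster, a lower number that the compound crosses the layer more slowly), compound 1 `CCOC(=O)c1c(-c2cccc(Cl)c2)[nH]c2cc(OC)ccc2c1=O` gives 950 10^-6 cm/s and compound 2 `CCOC(=O)c1c(-c2cccc(Cl)c2)[nH]c2cc(OC)c(F)cc2c1=O` gives 410 10^-6 cm/s as the lower of the two numbers. Among the measured compounds shown here, the one measured step of a 2.3-fold lower number from compound 1 to compound 2 (0.36 log units; beyond the scatter) is a fluoro in place of hydrogen, a different change, and serves only as a guide to size. Compound 3 `CCOC(=O)c1c(-c2cc(F)cc(OC)c2)[nH]c2cc(OC)c(F)cc2c1=O` carries 3-fluoro-5-methoxyphenyl in place of 3-chlorophenyl on an aromatic carbon, with 3-fluoro-5-methoxyphenyl in place of 3-chlorophenyl on an aromatic carbon as the counted difference. For the measured compounds named here, no measured step covers this replacement, so in this assay a small move is expected, leaning slightly downward and staying within the scatter. The estimated move is a 1.3-fold lower number from compound 2 to compound 3 (0.11 log units; within the scatter) in this reading. Compound 3 is expected at 320 10^-6 cm/s with a range from 140 10^-6 cm/s to 700 10^-6 cm/s as its span.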

Compound 3, apparent permeability in the ADME assay: 230 10^-6 cm/s
Beside the measured number, compound 3's estimate is 1.4-fold (0.14 log units) above it; the measured number falls inside the stated range.
By their numbers in the ADME assay, from the lowest: compounds 3 and 2 (each within the scatter of the next); then compound 1.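

In the ADME assay, 3-fluoro-5-methoxyphenyl in place of 3-chlorophenyl, on the aromatic carbon next to the ring nitrogen, gives a 1.8-fold lower number from compound 2 to compound 3 (0.25 log units; within the scatter), so this read-out does not separate the two groups. In a physicochemical assay for solubility, at pH 7.4 (on this read-out higher numbers stand for higher solubility and lower numbers for lower solubility), compound 2 gives 20000 nM and compound 3 gives 7500 nM. In the physicochemical assay, the same replacement does separate them, and this is the only change at this position shown so far: the measured solubility of compound 2, 20000 nM, and of compound 3, 7500 nM, a 2.7-fold lower number (0.43 log units; beyond the scatter)

The fluoro and methoxy groups enter together, so the data cannot assign the solubility step to either one. Also open, going by these compounds, is how an amine or a carboxylic acid on this ring would read.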